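A Distal Aryl Swap and Acid Dissociation

The source may hold more compounds than are shown below. What is called first, only, known or untested is meant among the compounds shown, and "the series" means these compounds.

Compound 3 `COc1ccc(F)cc1CNCCCNc1ccnc2cc(Cc3ccc(F)cc3Cl)ccc12` carries a 2-chloro-4-fluorobenzyl group on the core it shares with compound 1 `COc1ccc(F)cc1CNCCCNc1ccnc2cc(C3CCCCC3)ccc12` and compound 2 `COc1ccc(F)cc1CNCCCNc1ccnc2cc(CC(C)C)ccc12`. In a physicochemical assay for acid dissociation, compound 3 gives 9.47, level with compound 1 at 9.47 and with compound 2 at 9.47. The three measured steps all sit within the scatter: no change at the digits printed from compound 1 to compound 2 (within the scatter), no change at the digits printed from compound 1 to compound 3 (within the scatter) and no change at the digits printed from compound 2 to compound 3 (within the scatter). Compound 4 `COc1ccc(-c2ccc3c(NCCCNCc4cc(F)ccc4OC)ccnc3c2)cc1` has not yet been measured in this assay. It differs from compound 3 as follows: 4-methoxyphenyl in place of 2-chloro-4-fluorobenzyl on an aromatic carbon. Every recorded step bears on this one, as each likewise exchanges the group held on an aromatic carbon of the core, and none shifted the read-out beyond the scatter. Isobutyl in place of cyclohexyl left the value unchanged, 2-chloro-4-fluorobenzyl in place of cyclohexyl did the same, and 2-chloro-4-fluorophenyl in place of isopropyl on the saturated chain carbon did the same again. On that basis the expected step from compound 3 to compound 4 in this assay is no change at the digits printed from compound 3 to compound 4 (within the scatter), no movement beyond the scatter in either direction. Compound 4 is therefore estimated to give 9.47 in this assay, with a range from 9.17 to 9.77.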

Compound 4, acid dissociation constant: 9.47
Compound 4: the middle estimate sits on the measured number at the digits printed; the range from low to high includes it.
By their numbers in this assay, from the lowest: compounds 1, 2, 3 and 4 (each within the scatter of the next).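

In this assay, 4-methoxyphenyl on this aromatic carbon brings the first oxygen and the first hydrogen-bond acceptor to this position among the compounds shown, yet the result is no change at the digits printed from compound 3 to compound 4 (within the scatter), so the read-out holds when a 2-chloro-4-fluorobenzyl group with chlorine and fluorine gives way to a group with neither halogen. The same group also matches the two saturated substituents, with no change at the digits printed from compound 2 to compound 4 (within the scatter) against isobutyl and no change at the digits printed from compound 1 to compound 4 (within the scatter) against cyclohexyl, and so all four groups on this carbon, saturated or aromatic, branched or cyclic, with or without oxygen, are level in this read-out at the digits printed. Nothing in the material at hand explains why this position makes so little difference here.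

The compounds shown leave open whether a group such as an amine or a carboxylic acid on this same aromatic carbon would also leave the value in place. Among the compounds shown here, they also leave open whether a change in another part of the shared core, such as a longer chain in place of the one all four compounds carry, would move it.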